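The compounds below may be only part of what the source reports. "The series", "measured", "known", "first", "only" and "open" are said of these compounds alone.

The series shares one core, and compound 1 `COc1cc(Nc2ncc(C(F)(F)F)c(N3Cc4cccc(N(C)S(C)(=O)=O)c4C3)n2)cc(OC)c1` carries a 3,5-dimethoxyphenyl on the amino nitrogen of that core. Going by the values given here, in a functional assay on A549 cells (Homo sapiens) for antiproliferative activity, read by spectrophotometry, with a stated time of 2 days (on this read-out higher numbers stand for weaker inhibition of growth and lower numbers for stronger inhibition of growth), compound 1 gives 24800 nM, the highest of the two numbers measured so far. The other measured member, compound 2 `COc1cc(N2CCN(C(C)=O)CC2)ccc1Nc1ncc(C(F)(F)F)c(N2Cc3cccc(N(C)S(C)(=O)=O)c3C2)n1`, reaches 3300 nM in this assay, a number lower than that of compound 1 by a gap that lies beyond the scatter. Compound 3 `Cc1ccc(Nc2ncc(C(F)(F)F)c(N3Cc4cccc(N(C)S(C)(=O)=O)c4C3)n2)c(C)c1` has not yet been measured in this assay; it differs from compound 1 in one place: 2,4-dimethylphenyl in place of 3,5-dimethoxyphenyl on a nitrogen on an aromatic ring. Among the compounds with values here, no step between measured compounds speaks to this particular change, so it is expected that the number for compound 3 in this assay will stay close to that of compound 1, with the step of a 1.1-fold higher number from compound 1 to compound 3 (0.05 log units; within the scatter) estimated to lie within the scatter. Compound 3 is therefore estimated at 28000 nM in this assay, within a range from 8000 nM to 100000 nM.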

Compound 3, concentration for 50% growth inhibition: 20700 nM
Estimate against measurement, compound 3: 1.4-fold (0.13 log units) above; the measured number falls inside the stated range.
By their numbers in this assay, from the lowest: compound 2; then compounds 3 and 1 (each within the scatter of the next).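

At the nitrogen on an aromatic ring of the shared core, replacing 3,5-dimethoxyphenyl with 2,4-dimethylphenyl gives a 1.2-fold lower number from compound 1 to compound 3 (0.08 log units; within the scatter) in this assay and leaves the number within the usual scatter. Going by these compounds alone, this is the first direct reading at this place: an all-carbon dimethyl-substituted phenyl, without the oxygen atoms of the dimethoxy group and with its substituents at different ring positions, cannot be told apart from compound 1 in this measurement. Nothing at hand explains this outcome, and no separate measurement bears on it.

Within the data shown here, the result covers only this one exchange, so the effects of the oxygen atoms and of the substituent positions cannot be separated. It also leaves open how this number would respond to a phenyl ring carrying a morpholine, a primary amine or a carboxylic acid at this place.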